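The source may report more compounds than this note shows. Statements on the series, on what has been measured and on what is new or still open speak of the compounds shown alone.

Measured in a functional assay on YAC-1 cells (Mus musculus) for activation; on this read-out lower numbers stand for an effect already at smaller amounts and higher numbers for an effect only at larger amounts of compound:
- compound 1 (`C=CCn1c(=O)n(CCCC)c2nc(N)nc(O)c21`): 4 uM
- compound 2 (`C=CCn1c(=O)n(C2C=CC(CO)O2)c2nc(N)nc(O)c21`): 11 uM

Compound 2 holds the higher of the two numbers. For the measured compounds named here, the only measured step is a 2.8-fold higher number from compound 1 to compound 2 (0.44 log units; beyond the scatter). That step exchanges a different group, and the allyl stays unchanged in both compounds, so it bears on the next change only indirectly.

Compound 3 (`CCCn1c(=O)n(C2C=CC(CO)O2)c2nc(N)nc(O)c21`) differs from compound 2 by ethyl in place of vinyl on a saturated chain carbon bound to an aromatic nitrogen. This places ethyl in place of vinyl on a saturated chain carbon bound to an aromatic nitrogen, or allyl to propyl. Going by the values given here, no measured pair tests this exchange, so no step beyond the scatter is expected in this assay, and neither direction is favoured. The expectation therefore starts from compound 2 at 11 uM. The expected change is a 1.1-fold lower number from compound 2 to compound 3 (0.04 log units; within the scatter). For compound 3 the estimated value is 10 uM, with an expected range of 4 uM to 25 uM.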

Compound 3, concentration for half-maximal effect: 14 uM
Compound 3: middle estimate off by 1.4-fold (0.15 log units), on the low side; low and high end bracket the measured number.
By their numbers in this assay, from the lowest: compound 1; then compounds 2 and 3 (each within the scatter of the next).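

In this assay the exchange of vinyl for ethyl on a saturated chain carbon bound to an aromatic nitrogen gives a 1.3-fold higher number from compound 2 to compound 3 (0.10 log units; within the scatter) and so does not separate the two compounds. At this position, allyl and propyl therefore cannot be told apart on this read-out, and losing the double bond outside aromatic rings brings no change beyond the scatter in the setting of compound 3. No measurement bears on why this exchange leaves the number within the scatter.

As far as these compounds go, it remains open whether a longer chain, a benzyl group or an amine on this chain would move the number beyond the scatter. From the compounds shown here alone, it is also open whether allyl and propyl would match as closely with the butyl of compound 1 in place of the five-membered ring group.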